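Compound 2 to compound 3: a 2-methoxyethyl amide

This account rests on a few compounds, and the source may have more. Where it says the series, first, only, none or still open, it means among the compounds named here.

Measured in a physicochemical assay for solubility, read by HPLC, in phosphate buffer, with a stated time of 20 h, at pH 7.4; a lower number here means a less soluble compound, a higher number a more soluble compound:
Compound 1 `O=C(O)C[C@H]1CC[C@H](c2ccc(C(=O)Nc3nnc(CCC4CCCO4)s3)cc2)CC1`: 90000 nM
Compound 2 `NC(=O)C[C@H]1CC[C@H](c2ccc(C(=O)Nc3nnc(Cc4ccccc4)s3)cc2)CC1`: < 2000 nM (a limit, not a number)

Of these two, only compound 1 has a true number, 90000 nM. Compound 2 has no number of its own, and its < 2000 nM is a limit of this assay.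

Compound 3 `COCCNC(=O)C[C@H]1CC[C@H](c2ccc(C(=O)Nc3nnc(Cc4ccccc4)s3)cc2)CC1` keeps the rest of compound 2 and changes in one place, with 2-methoxyethyl in place of hydrogen on an amide-type nitrogen. Among the compounds with values here, no measured pair shows this change. The expectation therefore rests on compound 2 alone, and no step beyond the usual scatter is expected in either direction. The estimated change is a number no lower from compound 2 to compound 3 (the limit leaves the size open). A second limit is about as likely as a number. In this assay the expected value for compound 3 is 2000 nM, with an estimated range from 600 nM to 7000 nM.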

Compound 3, solubility: < 2000 nM
Compound 3: a limit, no number; the forecaster's own chance of this, stated with the estimate: 50%; the middle value sits exactly at the limit.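

In this assay compound 3 gives < 2000 nM as a limit and not a number. Compound 2 likewise has only a limit, and no step can be read from compound 2 to compound 3. As far as these compounds go, whether 2-methoxyethyl in place of hydrogen on the amide-type nitrogen moves the value at all stays open.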